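The compounds below may be only part of what the source reports. "The series", "measured", "known", "first", "only" and "open" are said of these compounds alone.

Series notes. Compound 1 `Cc1cnn(C(=O)NCc2ccc(OCc3ccccc3)cc2)c1` gives 1000 nM in an assay on membranes from brain for binding affinity to Monoglyceride lipase (Mus musculus), read by fluorescence, with stated times of 1 h and 30 min; a lower number here means a stronger inhibitor, a higher number a weaker inhibitor. Compound 2 `Cc1cnn(C(=O)N2CCCN(Cc3ccc(OCc4ccccc4)cc3)CC2)c1` gives 9500 nM in this assay, and compound 3 `Cc1cnn(C(=O)N(C)CCN(C)Cc2ccc(OCc3ccccc3)cc2)c1` gives 1200 nM in this assay. Compound 3 holds the second highest of the three numbers: its value and that of compound 1 lie within the scatter of each other, while compound 2 stands beyond the scatter at a higher number. The next compound, compound 4 `CN(CCN(C)C(=O)n1cccn1)Cc1ccc(OCc2ccccc2)cc1`, differs from compound 3 only by hydrogen in place of methyl on an aromatic carbon, that is 4-methyl-1H-pyrazol-1-yl to 1H-pyrazol-1-yl. Within the data shown here, no measured pair shows this change, so no step size can be read from the data; for compound 4 a step of a 1.3-fold higher number from compound 3 to compound 4 (0.12 log units; within the scatter) is expected, with no clear direction beyond the scatter. Compound 4 is estimated at 1600 nM in this assay, with a range from 600 nM to 4500 nM.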

Compound 4, half-maximal inhibitory concentration: 660 nM
Compound 4: middle estimate off by 2.4-fold (0.38 log units), on the high side; low and high end bracket the measured number.
By their numbers in this assay, from the lowest: compounds 4, 1 and 3 (each within the scatter of the next); then compound 2.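

In this assay, the change from 4-methyl-1H-pyrazol-1-yl to 1H-pyrazol-1-yl now has a measured size (a 1.8-fold lower number from compound 3 to compound 4 (0.26 log units; within the scatter)). On this pair, removing the methyl therefore gives no change beyond the scatter, so the methyl is not needed to retain the activity seen for compound 3. No measurement available here gives a reason for this result. The compounds shown leave open how an ethyl group, a chlorine atom or a nitrile would read at this position, and whether the same change gives a similar step on the cores of compound 1 and compound 2.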